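The source may hold more compounds than are shown below. What is called first, only, known or untested is meant among the compounds shown, and "the series" means these compounds.

In a functional assay on HL-60 cells (Homo sapiens) for inhibition, read by CCK-8 assay, with a stated time of 48 h, tested at 20 uM (on this read-out lower numbers stand for less inhibition of growth and higher numbers for more inhibition of growth at the one concentration tested), compound 3 `Cc1ccc(S(=O)(=O)Oc2ccccc2/C=C(\C#N)C(=O)Nc2nnc(Cc3ccc(Cl)cc3)s2)cc1` gives 15%. That lies within the scatter of compound 1 `COc1ccc(Cc2nnc(NC(=O)/C(C#N)=C/c3ccccc3OS(=O)(=O)c3ccc(Cl)cc3)s2)cc1`, at 20%, and clearly under compound 2 `N#C/C(=C\c1ccccc1OS(=O)(=O)c1ccc(Cl)cc1)C(=O)Nc1nnc(-c2cccc(F)c2)s1`, at 42%. Compound 4 `N#C/C(=C\c1ccccc1OS(=O)(=O)c1ccc(Cl)cc1)C(=O)Nc1nnc(Cc2ccc(Cl)cc2)s1` differs from compound 3 in one place: chloro in place of methyl on an aromatic carbon. This is chloro in place of methyl on an aromatic carbon, which turns (4-methylphenyl)sulfonyl into (4-chlorophenyl)sulfonyl. For the measured compounds named here, no measured pair isolates this swap. Going by the values given here, the only measured step, a number 22 percentage points higher from compound 1 to compound 2 (beyond the scatter), is modest and comes from a different change, 3-fluorophenyl in place of 4-methoxybenzyl, so it says little about this one. Some indirect guidance comes from compound 1, which already carries (4-chlorophenyl)sulfonyl and, at 20%, stays within the scatter of compound 3, although the two also differ elsewhere. No step beyond the scatter is therefore expected in this assay, and the estimated change is a number 5 percentage points higher from compound 3 to compound 4 (within the scatter). Compound 4 is expected at about 20%, with an estimated range of 8% to 35%.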

Compound 4, percent growth inhibition at one concentration: 15%
The estimate for compound 4 lay 5 percentage points above the measured number; low and high end bracket the measured number.
By their numbers in this assay, from the lowest: compounds 3, 4 and 1 (each within the scatter of the next); then compound 2.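

In this assay, for the compounds shown here, chloro in place of methyl on the aromatic carbon of the sulfonyl-bearing ring gives no change at the digits printed from compound 3 to compound 4 (within the scatter) and is the first direct reading of this swap, so (4-methylphenyl)sulfonyl and (4-chlorophenyl)sulfonyl cannot be told apart here, at least with 4-chlorobenzyl at the other end. Going by these compounds alone, with (4-chlorophenyl)sulfonyl held fixed, chloro in place of methoxy on the benzyl group gives a number 5 percentage points lower from compound 1 to compound 4 (within the scatter) and 4-chlorobenzyl in place of 3-fluorophenyl gives a number 27 percentage points lower from compound 2 to compound 4 (beyond the scatter) and only this last change clearly moves the number. Nothing available explains any of these steps. Going by these compounds, whether the swap would also leave the number unchanged with 3-fluorophenyl at the other end remains open. So does the effect of a quite different group on this ring carbon, such as an amine or a carboxylic acid.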